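Removing the ethoxycarbonyl group from compound 2

The source may hold more compounds than are shown below. What is called first, only, known or untested is meant among the compounds shown, and "the series" means these compounds.

Values from a functional assay on SGC-7901 cells (Homo sapiens) for antiproliferative activity, read by MTT assay, with a stated time of 72 h (on this read-out lower numbers stand for stronger inhibition and higher numbers for weaker inhibition), for the measured compounds:
Compound 1 `CCOC(=O)c1cc(-c2cc(OC)c(OC)c(OC)c2)c(-c2ccc(OC)c([N+](=O)[O-])c2)s1` gives 18100 nM
Compound 2 `CCOC(=O)c1cc(-c2cc(OC)c(OC)c(OC)c2)c(-c2ccc3ccccc3c2)s1` gives 4340 nM
Compound 3 `CCOC(=O)c1cc(-c2cc(OC)c(OC)c(OC)c2)c(-c2ccc(OC)c(O)c2)s1` gives 1580 nM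

Compound 2 holds the middle place of the three numbers, with compound 3 lower and compound 1 higher. The next compound to be measured is compound 4 `COc1cc(-c2ccsc2-c2ccc3ccccc3c2)cc(OC)c1OC` and its difference from compound 2 is hydrogen in place of ethoxycarbonyl on an aromatic carbon in one place: hydrogen in place of ethoxycarbonyl on an aromatic carbon, next to the ring sulfur.

In the measured steps, a 4.2-fold lower number from compound 1 to compound 2 (0.62 log units; beyond the scatter) and a 2.7-fold lower number from compound 2 to compound 3 (0.44 log units; beyond the scatter) are modest and an 11-fold lower number from compound 1 to compound 3 (1.06 log units; beyond the scatter) is large, yet each leaves the ethoxycarbonyl group in place. The data therefore give no direct measure of this change. With compound 2 at 4340 nM as the anchor, no step beyond the scatter is expected in this assay and the uncertainty in either direction is wide. The estimated step is a 1.4-fold higher number from compound 2 to compound 4 (0.14 log units; within the scatter) on this reasoning. Compound 4 is estimated at 6000 nM with an expected range from 1500 nM as lower end to 25000 nM as upper end.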

Compound 4, half-maximal inhibitory concentration: 5890 nM
Beside the measured number, compound 4's estimate is 1.0-fold (0.01 log units) above it, within the range that was stated.
By their numbers in this assay, from the lowest: compound 3; then compounds 2 and 4 (each within the scatter of the next); then compound 1.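

In this assay, among these compounds, hydrogen in place of ethoxycarbonyl next to the ring sulfur gives a 1.4-fold higher number from compound 2 to compound 4 (0.13 log units; within the scatter); this is the first reading at this position, as compounds 1, 2 and 3 all keep the ethoxycarbonyl group and differ only in the other aromatic group. With naphthalen-2-yl in place, the 5 heavy atoms and 2 hydrogen-bond acceptors of the ethoxycarbonyl group can therefore leave without a step beyond the scatter. No data at hand give a reason for this result.

From the compounds shown here alone, whether the same holds with the 3-hydroxy-4-methoxyphenyl group of compound 3 or the 4-methoxy-3-nitrophenyl group of compound 1 remains open, as only the naphthalen-2-yl pair reads on this change. Also open, going by these compounds, is how a carboxylic acid or an aminomethyl group at this position would read in this assay.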